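A few compounds are considered here, and "the series" means these few. Any claim that something is new, unique, unknown or untested is made for them only; others in the source may bear on it.

Compound 1 `O=C1Nc2ccccc2[C@]12N[C@H](c1ccccc1)[C@H](c1cccs1)[C@@]21CCc2c([nH]c3ccc(Cl)cc23)C1=O` and compound 2 `COc1ccc([C@H]2[C@@H](c3ccccc3)N[C@@]3(C(=O)Nc4ccccc43)[C@]23CCc2c([nH]c4ccc(C)cc24)C3=O)cc1` share one core and were both tested in a functional assay on MCF7 cells (Homo sapiens) for antiproliferative activity, read by MTT assay, with a stated time of 48 h; a lower number here means a stronger inhibitor, a higher number a weaker inhibitor. Compound 1 gives 13000 nM. Compound 2 gives 18000 nM, and the two numbers lie within the scatter of each other, so neither compound can be called the stronger inhibitor. Compound 3 `COc1ccc([C@H]2[C@@H](c3ccccc3)N[C@@]3(C(=O)Nc4ccccc43)[C@]23CCc2c([nH]c4ccc(Cl)cc24)C3=O)cc1` is compound 2 with a (chloro in place of methyl on an aromatic carbon). Going by the values given here, compound 1 carries chloro at the same spot but differs from compound 2 elsewhere too, so no clean step between measured compounds exists. The expected step is a 1.3-fold lower number from compound 2 to compound 3 (0.11 log units; within the scatter), within the scatter. Compound 3 is estimated at 14000 nM, between 6000 nM and 35000 nM.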

Compound 3, half-maximal inhibitory concentration: 19000 nM
Compound 3: middle estimate off by 1.4-fold (0.13 log units), on the low side, within the range that was stated.
By their numbers in this assay, from the lowest: compounds 1, 2 and 3 (each within the scatter of the next).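

Chloro in place of methyl on an aromatic carbon gives a 1.1-fold higher number from compound 2 to compound 3 (0.02 log units; within the scatter) in this assay and provides the first clean reading at this position: the two groups cannot be told apart here. 4-Methoxyphenyl in place of thiophen-2-yl on a saturated ring carbon gives a 1.5-fold higher number from compound 1 to compound 3 (0.16 log units; within the scatter) and is likewise too small a step to separate the two groups. No measurement shown here explains these results.

From the compounds shown here alone, whether an amine or a carboxylic acid on that aromatic carbon would move the number beyond the scatter remains open.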